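Swapping Chloro for Trifluoromethyl on the Urea Aryl Ring

A few compounds are considered here, and "the series" means these few. Any claim that something is new, unique, unknown or untested is made for them only; others in the source may bear on it.

Measured so far:
compound 1 `O=C(Nc1cccc(-n2cc(-c3ccncc3)c(-c3ccc(Cl)c(O)c3)n2)c1)Nc1ccc(Cl)c(Cl)c1` — > 32500 nM
compound 2 `O=C(Nc1cccc(-n2cc(-c3ccncc3)c(-c3ccc(Cl)c(O)c3)n2)c1)Nc1cc(C(F)(F)F)cc(C(F)(F)F)c1` — 3090 nM

In a functional assay on SK-MEL-28 cells (Homo sapiens) for inhibition, read by sulforhodamine B assay, with a stated time of 48 h (a lower number here means that less compound is tolerated, a higher number that more compound is tolerated), compound 1 gives > 32500 nM, which is a limit of the assay rather than a number. Compound 1 thus sits at the limit of > 32500 nM in this assay, at which 1 of the 2 values shown sits. Compound 2, which carries two trifluoromethyl groups on the same ring, gives 3090 nM in this assay. Within the data shown here, no step between compound 1 and compound 2 is computed here, so the two values can only be set side by side: compound 2 gives a number where compound 1 gives a limit.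

Compound 3 `O=C(Nc1cccc(-n2cc(-c3ccncc3)c(-c3ccc(Cl)c(O)c3)n2)c1)Nc1ccc(Cl)c(C(F)(F)F)c1` has not yet been measured in this assay. It differs from compound 1 by trifluoromethyl in place of chloro on an aromatic carbon. Among the measured compounds shown here, no measured step covers this change, so the size of the effect is an expectation only. For the measured compounds named here, since compound 2, with trifluoromethyl groups in place of both chloro groups, gives 3090 nM, the single exchange in compound 3 is expected to move the value downward by an at least 3.2-fold lower number from compound 1 to compound 3 (0.51 log units; beyond the scatter), beyond the usual scatter. Compound 3 is therefore estimated at 10000 nM, with a range from 3000 nM to 32500 nM.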

Compound 3, concentration lethal to 50% of the cells: 12400 nM
Beside the measured number, compound 3's estimate is 1.2-fold (0.09 log units) below it; the range from low to high includes it.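

In this assay, replacing one chloro group of the 3,4-dichlorophenyl ring with trifluoromethyl, which gives the 4-chloro-3-(trifluoromethyl)phenyl ring, produces an at least 2.6-fold lower number from compound 1 to compound 3 (0.41 log units; beyond the scatter). Among these compounds, this is the first readable step: only this one group changes, the other chloro group stays in place, and the rest of the structure is the same, so a single exchange at this position is enough to move the value beyond the usual scatter. The step has only a minimum size, as compound 1 gives a limit and not a number: the limit of > 32500 nM in this assay, at which 1 of the 3 values shown sits.

As far as these compounds go, what remains open is whether this position responds to trifluoromethyl in particular or would also respond to other groups in the same place, such as a methyl group, a methoxy group, a nitrile or a simple amine. It is also unclear whether the step would keep its size if the remaining chloro group were replaced by fluoro or by hydrogen, and nothing here explains why the value falls.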